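Capping the phenol of a hexyl nitrate cinnamate ester

The source may report more compounds than this note shows. Statements on the series, on what has been measured and on what is new or still open speak of the compounds shown alone.

The set comprises three measured compounds and one that awaits its number. Compound 1 `O=C(/C=C/c1ccc(OCCCCCCO[N+](=O)[O-])c(O)c1)OCCCCCCO[N+](=O)[O-]` carries two nitrate-bearing chains on a shared core. Compound 2 `COc1cc(/C=C/C(=O)OCCCO[N+](=O)[O-])ccc1O` keeps a free phenol and a shorter chain, and compound 3 `COc1cc(/C=C/C(=O)Oc2cccc(OCc3c(-c4ccccc4)no[n+]3[O-])c2)ccc1O` carries a furoxan-bearing aryl ester. In a functional assay on NCI-H1299 cells (Homo sapiens) for cytotoxicity, read by resazurin assay, with a stated time of 72 h (on this read-out lower numbers stand for stronger inhibition and higher numbers for weaker inhibition), compound 1 is reported only as a limit, > 50000 nM. In this assay compound 3 likewise gives only a limit, > 50000 nM. In this assay compound 2 gives a number, 28300 nM. Going by the values given here, compound 1 therefore stands at the limit of > 50000 nM in this assay, at which 2 of the 3 values shown sit, and no measured step from it to another compound is recorded; of compound 1 and compound 2 one can say only what the two values show.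

Compound 4 `COc1cc(/C=C/C(=O)OCCCCCCO[N+](=O)[O-])ccc1OCCCCCCO[N+](=O)[O-]` differs from compound 1 by methyl in place of hydrogen on an oxygen on an aromatic ring; cut one bond further out, the change reads hydroxy to methoxy. With compound 1 known only as a limit, no step is expected to be resolved beyond the scatter, and compound 4 is expected to sit in the same region, so the expected step that the limit leaves unreadable from compound 1 to compound 4 is estimated to be essentially none. Compound 4 is estimated at 60000 nM, within 25000 nM to 150000 nM, with a fair chance that this assay again reports only a limit.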

Compound 4, half-maximal inhibitory concentration: > 50000 nM
Compound 4 ended at the assay's limit (the forecaster's own chance of this, stated with the estimate: 65%); the middle value lies beyond the limit too.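

In this assay compound 4 gives > 50000 nM, which is a limit. Going by these compounds alone, compound 1 is also known only as a limit, so no step between compound 1 and compound 4 can be read. Compound 4 therefore stands at: the limit of > 50000 nM in this assay, at which 3 of the 4 values shown sit.

On these data alone, whether hydroxy to methoxy at this place changes the cytotoxicity at all remains open, as neither compound has a number.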